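Stereocentre left undefined in the aminothiazole amide

The source may hold more compounds than are shown below. What is called first, only, known or untested is meant among the compounds shown, and "the series" means these compounds.

Compound 1 `Cc1nc(N)sc1CCCNC(=N)NC(=O)C[C@@H](C)c1ccccc1` gives 102 nM in a functional assay on cardiac atrium for agonist activity at histamine H2 receptor (Cavia porcellus) (on this read-out lower numbers stand for an effect already at smaller amounts and higher numbers for an effect only at larger amounts of compound), and stands as the higher of the two numbers recorded; the nearest is compound 2 `C[C@H](CC(=O)NC(=N)NCCCc1c[nH]cn1)c1ccccc1` with 93.3 nM. Among the compounds with values here, the only step between measured compounds, a 1.1-fold lower number from compound 1 to compound 2 (0.04 log units; within the scatter), exchanges the heteroaryl group on the chain and carries no information about configuration.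

Compound 3 `Cc1nc(N)sc1CCCNC(=N)NC(=O)CC(C)c1ccccc1` keeps every atom and bond of compound 1 and differs only in the drawing of one centre: the two compounds have the same atoms and bonds; at least one stereo element is drawn with a configuration in one of them and without one in the other: 1 of 2 stereo elements differ; a stereocentre at a saturated chain carbon is drawn R in compound 1 and without a configuration in compound 3. Within the data shown here, no measured step concerns such a change, so the series gives no direct guide. If compound 3 is a mixture at that centre, its number is expected to lie close to or somewhat higher than that of compound 1. A step of a 1.6-fold higher number from compound 1 to compound 3 (0.20 log units; within the scatter) is expected in this assay, within the scatter or a little beyond it. For compound 3 the estimate is 160 nM, with a range from 70 nM to 400 nM.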

Compound 3, half-maximal effective concentration: 49 nM
The estimate for compound 3 lay 3.3-fold (0.51 log units) above the measured number; measured number below the stated range.
By their numbers in this assay, from the lowest: compounds 3, 2 and 1 (each within the scatter of the next, the first and the last beyond it).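

In this assay, within the data shown here, the drawing of the stereocentre at the saturated chain carbon gives the first step beyond the scatter, though a modest one: a 2.1-fold lower number from compound 1 to compound 3 (0.32 log units; beyond the scatter). The earlier exchange of the heteroaryl group stayed within the scatter, so this centre is so far the only place in the series where the number moves beyond it. The step can rest only on the configuration at that centre: the fact that one of compounds 1 and 3 is drawn with a defined configuration and the other without, at the place where they differ.

Still open, from the compounds shown here alone, are the composition of compound 3 at that centre and the number the opposite configuration would give alone. Also open, going by these compounds, is whether the step recurs with the 1H-imidazol-4-yl group of compound 2, or with an ethyl group in place of the methyl on that carbon.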